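The source may hold more compounds than are shown below. What is called first, only, known or untested is meant among the compounds shown, and "the series" means these compounds.

Of the compounds shown here, three have been tested so far in an assay on isolated protein for inhibition of DNA topoisomerase 1 (Homo sapiens), with a stated time of 30 min, tested at 20 uM; a lower number here means a weaker effect, a higher number a stronger effect of the compound at the concentration tested. Compound 1, with the structure `Oc1cccc(-c2cc(-c3ccco3)cc(-c3ccccc3O)n2)c1`, gives 0%. Compound 2, with the structure `Oc1ccc(-c2cc(-c3ccco3)cc(-c3ccccc3O)n2)cc1`, gives 0%. The change from compound 1 to compound 2 is 4-hydroxyphenyl in place of 3-hydroxyphenyl on an aromatic carbon, and the step it made in this assay is no change at the digits printed from compound 1 to compound 2 (within the scatter). Compound 3, with the structure `Oc1ccc(-c2cc(-c3cccnc3)cc(-c3cccc(O)c3)n2)cc1`, gives 2.8%. Its value lies within the scatter of the values of compound 1 and compound 2, so the three measured compounds cannot be told apart. The difference between the core of compound 1 and the core of compound 3 is not broken down here.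

Compound 4, with the structure `Oc1ccc(-c2cc(-c3cccnc3)cc(-c3ccc(O)cc3)n2)cc1`, has not yet been measured. It differs from compound 3 by 4-hydroxyphenyl in place of 3-hydroxyphenyl on an aromatic carbon. This is the same kind of change as that from compound 1 to compound 2, but the surroundings differ: in compound 1 the place is meta to a 2-hydroxyphenyl group and to a furan-2-yl group, whereas in compound 3 it is meta to a 4-hydroxyphenyl group and to a pyridin-3-yl group. Because that earlier step was no change at the digits printed from compound 1 to compound 2 (within the scatter), the step from compound 3 to compound 4 is expected to be about as small, namely a number 0.8 percentage points lower from compound 3 to compound 4 (within the scatter). Compound 4 is therefore expected to give about 2% in this assay, most likely between 0% and 10%.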

Compound 4, a percentage reported as inhibition, at one concentration (the size of the read-out at that concentration, not a potency): 5%
For compound 4 the middle estimate is 3 percentage points below the measured one; low and high end bracket the measured number.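

In this assay, putting 4-hydroxyphenyl in place of 3-hydroxyphenyl on the core of compound 3 gives a number 2.2 percentage points higher from compound 3 to compound 4 (within the scatter), and the same change on the two cores can be compared directly: the same change on two cores in this assay, no change at the digits printed (within the scatter) from compound 1 to compound 2 and a number 2.2 percentage points higher (within the scatter) from compound 3 to compound 4, 2.2 percentage points apart, within the scatter of two such steps So in these two pairs the change carries from one core to the other without any difference that can be detected, and on neither core does it separate the two compounds involved. This does not show that the change is without consequence in general, since all four numbers are small and lie close to no inhibition at all, and a change that does nothing visible on such weak compounds might still matter on a compound with a clear effect.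

The compounds shown leave open whether the core of compound 1 and the core of compound 3 differ in their own right, since furan-2-yl and pyridin-3-yl are never exchanged with everything else held the same, and 2-hydroxyphenyl is never exchanged alone on the core of compound 3. They also leave open whether a group other than a hydroxyl on these phenyl rings, such as an amine, a carboxylic acid or a longer chain ending in an amine, would give inhibition clearly stronger than that seen here.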